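The source may report more compounds than this note shows. Statements on the series, on what has been measured and on what is new or still open speak of the compounds shown alone.

Measured in a functional assay on MV4-11 cells (Homo sapiens) for cytotoxicity, read by MTT assay, with a stated time of 72 h; a higher number here means a weaker inhibitor, a lower number a stronger inhibitor
- compound 1 `CCOC(=O)c1csc2nc(-c3ccc(NC(=O)Nc4ccc(Br)cn4)cc3)cn12` gives 2440 nM as a number
- compound 2 `C=CC(=O)Nc1cccc(-c2cn3c(C(=O)OCC)csc3n2)c1` gives > 20000 nM as a limit of the assay

Of the two, only compound 1 has a measured number, so 2440 nM is the sole numerical reference for the series. Compound 3 `CCOC(=O)c1csc2nc(-c3ccc(NS(=O)(=O)c4ccc(C)cc4)cc3)cn12` keeps the core of compound 1 and carries (4-methylphenyl)sulfonyl in place of (5-bromopyridin-2-yl)carbamoyl on a nitrogen on an aromatic ring. Among the measured compounds shown here, no measured step sizes this change, so the expectation is an uncertain, moderate move toward weaker inhibition in this assay. The expected step is wide in its margins (a 2.5-fold higher number from compound 1 to compound 3 (0.39 log units; beyond the scatter)). For compound 3 the expected value is 6000 nM with an estimated range from 1500 nM to 20000 nM in this read-out.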

Compound 3, half-maximal inhibitory concentration: > 20000 nM
Compound 3: only a limit was reported; the forecaster's own chance of this, stated with the estimate: 25%; middle value at least 3.3-fold (0.52 log units) away from the limit.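

In this assay, the nitrogen on an aromatic ring proves sensitive to the group it carries: (4-methylphenyl)sulfonyl in place of (5-bromopyridin-2-yl)carbamoyl gives an at least 8.1-fold higher number from compound 1 to compound 3 (0.91 log units; beyond the scatter). For compound 3, > 20000 nM is a limit of the assay, not a number. The step therefore has a floor but no upper end, and the series offers little numerical range against which to size it: the limit of > 20000 nM in this assay, at which 2 of the 3 values shown sit.

The compounds shown leave open whether the difference follows the carbamoyl part, the 5-bromopyridine part or the two together, since both leave in the same change. A plain phenylcarbamoyl group, without the bromine or the ring nitrogen, or a small acetyl group on the same nitrogen would help separate these parts.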